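The compounds below may be only part of what the source reports. "The series", "measured", "known", "first", "only" and "open" are said of these compounds alone.

Measured in a functional assay for inhibition, with Homo sapiens as the target; a lower number here means a stronger inhibitor, a higher number a weaker inhibitor:
Compound 1 `CCOC(=O)C(CCc1ccccc1)Nc1nc2ccccc2s1`: 520 nM
Compound 2 `COC(=O)[C@@H](CC1CCCCC1)Nc1nc2ccccc2o1`: 100 nM
Compound 3 `Fc1ccc(C(CC2CCCCC2)Nc2nc3ccccc3o2)cc1`: 170 nM

Compound 3 sits within the usual scatter of compound 2, while compound 1 shows a clearly higher number, so compound 3 is the more potent of that pair. Compound 4 `Clc1ccccc1C(CC1CCCCC1)Nc1nc2ccccc2o1` carries 2-chlorophenyl in place of 4-fluorophenyl on a saturated chain carbon bound to a nitrogen on an aromatic ring and a saturated chain carbon. Within the data shown here, no two measured compounds differ in one place only, so the data do not show what such a swap does in this assay. With nothing to suggest a large shift, no change beyond the scatter is expected, in either direction. The expected change is a 1.2-fold higher number from compound 3 to compound 4 (0.07 log units; within the scatter). For compound 4 the estimated value is 200 nM, with an expected range of 70 nM to 550 nM.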

Compound 4, half-maximal inhibitory concentration: 80 nM
Compound 4: the middle estimate sits 2.5-fold (0.40 log units) above what was measured; low and high end bracket the measured number.
By their numbers in this assay, from the lowest: compounds 4, 2 and 3 (each within the scatter of the next, the first and the last beyond it); then compound 1.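

In this assay, among these compounds, putting 2-chlorophenyl in place of 4-fluorophenyl on this saturated chain carbon gives a 2.1-fold lower number from compound 3 to compound 4 (0.33 log units; beyond the scatter) and provides the first comparison here of compounds differing in one place. The step is modest but beyond the usual scatter, so the group at this position can shift the number. Nothing available explains this shift. On these data alone, both the halogen and its printed ring position change in this swap, so their separate contributions remain open. Plain phenyl, 4-chlorophenyl and 2-fluorophenyl at this carbon would help separate them.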